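A Shorter Amine Tail on the Shared Core

This account rests on a few compounds, and the source may have more. Where it says the series, first, only, none or still open, it means among the compounds named here.

The three measured compounds share one core, carrying on its aromatic nitrogen a saturated chain that ends either in a basic ring or in a triazole bearing an acetal. In a functional assay on MDA-MB-231 cells (Homo sapiens) for cytotoxicity, read by MTT assay, with a stated time of 72 h (a lower number here means a stronger inhibitor, a higher number a weaker inhibitor), compound 1 `CN1CCN(CCCCCn2c3c(c4ccccc42)C(=O)c2c[n+]([O-])c4ccccc4c2C3=O)CC1` gives 2270 nM, the highest number among the three. Compound 2 `CC1(C)O[C@@H](CO)[C@H](Cn2cc(Cn3c4c(c5ccccc53)C(=O)c3c[n+]([O-])c5ccccc5c3C4=O)nn2)O1` gives 680 nM in this assay, and compound 3 `CC1(C)OCC(Cn2cc(Cn3c4c(c5ccccc53)C(=O)c3c[n+]([O-])c5ccccc5c3C4=O)nn2)O1` gives 230 nM. Among the compounds with values here, the only step between compounds that differ in one place is a 3.0-fold lower number from compound 2 to compound 3 (0.47 log units; beyond the scatter), and it concerns the acetal end of the triazole-bearing chain, not the amine-bearing chain of compound 1.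

Compound 4 `O=C1c2c[n+]([O-])c3ccccc3c2C(=O)c2c1c1ccccc1n2CCCCN1CCCCC1` differs from compound 1 by piperidin-1-yl in place of (4-methylpiperazin-1-yl)methyl on a saturated chain carbon, four bonds along the chain from an aromatic nitrogen. Within the data shown here, no measured pair shows a change of this kind, so the single measured step offers no direct guide; it only shows that trimming the far end of the chain on this core has shifted the number by a modest amount. He therefore expects a step of similar size or smaller from compound 1 to compound 4, and is uncertain about its direction, leaning toward a lower number. He estimates compound 4 at 1500 nM in this assay, within a range of 500 nM to 4500 nM, which corresponds to an expected 1.5-fold lower number from compound 1 to compound 4 (0.18 log units; within the scatter).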

Compound 4, half-maximal inhibitory concentration: 610 nM
The estimate for compound 4 lay 2.5-fold (0.39 log units) above the measured number, and the stated range covers the measured number.
By their numbers in this assay, from the lowest: compound 3; then compounds 4 and 2 (each within the scatter of the next); then compound 1.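

In this assay, the amine-bearing chain proves to be a place where the number moves: a 3.7-fold lower number from compound 1 to compound 4 (0.57 log units; beyond the scatter) accompanies the exchange of (4-methylpiperazin-1-yl)methyl for piperidin-1-yl on a saturated chain carbon, four bonds along the chain from an aromatic nitrogen. Within the data shown here, the earlier compounds offered only a 3.0-fold lower number from compound 2 to compound 3 (0.47 log units; beyond the scatter) at the acetal end of the triazole-bearing chain, so this is the first step read on the amine-bearing chain, and it too lies beyond the scatter. Nothing given here bears on why the number differs between these two compounds.

The change alters the ring and the length of the chain together, so the compounds shown cannot say how much of the step belongs to losing the 4-methylpiperazine ring and how much to the shorter tail. A 4-methylpiperazin-1-yl group on the shorter chain, or a piperidin-1-yl group on the longer one, would separate the two, while a morpholine ring or a dimethylamino group at the chain end would show how far the step extends to other amines.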